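The source may report more compounds than this note shows. Statements on the series, on what has been measured and on what is new or still open speak of the compounds shown alone.

Working notes on the series in a functional assay on CHO cells for agonist activity at Free fatty acid receptor 1 (Homo sapiens), read by a luciferase reporter; on this read-out lower numbers stand for smaller maximal responses and higher numbers for larger maximal responses.

Three compounds have numbers. Compound 1 `Cc1nc(-c2ccc(C(F)(F)F)cc2)sc1CNc1ccc(C(=O)O)cc1` gives 10% in this assay. Compound 3 `Cc1nc(-c2ccc(C(F)(F)F)cc2)sc1CNc1ccc(/C=C/C(=O)O)cc1` gives 95%. Compound 2 `O=C(O)CCCc1ccc(NCc2cccc(Oc3ccccc3)c2)cc1` gives 59%, which places compound 2 second of the three: compound 3 lies beyond the scatter above it, compound 1 beyond the scatter below it.

Among the measured compounds shown here, only one single-point step is available, a number 85 percentage points higher from compound 1 to compound 3 (beyond the scatter); it moves the acid out from the ring on a two-carbon linker, and the gain is large.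

Compound 4 `O=C(CCc1ccc(NCc2cccc(Oc3ccccc3)c2)cc1)N1CCCC1` has not been measured in this assay. It differs from compound 2 by (pyrrolidin-1-yl)carbonyl in place of carboxymethyl on a saturated chain carbon, two bonds along the chain from an aromatic carbon. This change does not keep the acid on a longer or shorter chain; it takes the acid away and leaves an amide in its place. For the measured compounds named here, no measured step covers such an exchange, so the one known step of a number 85 percentage points higher from compound 1 to compound 3 (beyond the scatter) bears on it only indirectly: it shows that the acid end of the molecule is where the read-out is most sensitive, and that changes there are large rather than within the scatter.

Given that, a downward step is expected for compound 4, estimated as a number 44 percentage points lower from compound 2 to compound 4 (beyond the scatter). The maximal response of compound 4 in this assay is expected near 15%, within 0% to 45%.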

Compound 4, largest response reached (reported as percent of maximum), in percent of the reference or control that the assay uses: 46%
The estimate for compound 4 lay 31 percentage points below the measured number; the whole stated range lies below it.
By their numbers in this assay, from the lowest: compound 1; then compound 4; then compound 2; then compound 3.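

In this assay the exchange of the carboxymethyl for (pyrrolidin-1-yl)carbonyl, which takes the carboxylic acid out of the molecule, gives a number 13 percentage points lower from compound 2 to compound 4 (beyond the scatter) and is only a modest change. Among the compounds shown here, until now every compound carried a carboxylic acid, and the one earlier step, a number 85 percentage points higher from compound 1 to compound 3 (beyond the scatter) as the acid moved out from the ring, made this end of the molecule look like a place where changes are large; on the phenoxy-bearing core, the amide compound 4 keeps a substantial maximal response at 46% in this assay, so a free acid at the chain end is not required for a clear response in this pair. No measurement shown here accounts for the retained response, and the cause of this small step remains unexplained.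

The compounds shown leave open whether the retained response depends on the pyrrolidine ring or on the amide carbonyl alone, which a dimethylamide, a primary amide or a methyl ester at the same chain position would help separate. They also leave open whether the same exchange would be as mild on the core of compound 3, where the acid sits on the 2-carboxyethenyl group.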